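Replacing the Brominated Biphenyl Arm with a Benzyloxy Group

The source may hold more compounds than are shown below. What is called first, only, known or untested is meant among the compounds shown, and "the series" means these compounds.

Measured compounds:
Compound 1, `CCC1(c2ccccc2)CC(=O)C(C(CC(=O)c2ccc(-c3ccc(Br)cc3)cc2)c2ccccc2)=C(O)O1`: 5740 nM
Compound 2, `CC1(c2ccccc2)CC(=O)C(C2CC(c3ccc(-c4ccc(Br)cc4)cc3)Cc3ccccc32)=C(O)O1`: 1800 nM

Of the compounds shown here, two sharing the same core have so far been tested in a functional assay on SK-OV-3 cells (Homo sapiens) for inhibition, with a stated time of 72 h; on this read-out lower numbers stand for stronger inhibition and higher numbers for weaker inhibition. Compound 1 gives 5740 nM, while compound 2 gives 1800 nM. Of the two, compound 2 has the lower number, and its gap to compound 1 lies beyond the usual scatter, so compound 2 is the more potent of the pair on this read-out.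

Compound 3, `CC1(c2ccccc2)CC(=O)C(C2CC(c3ccc(OCc4ccc(C(F)(F)F)cc4)cc3)Cc3ccccc32)=C(O)O1`, differs from compound 2 in a single place: (4-(trifluoromethyl)benzyl)oxy in place of 4-bromophenyl on an aromatic carbon. Among the measured compounds shown here, no measured pair of compounds isolates this particular change, so there is nothing in the numbers that tells how the read-out will respond to it. The estimated step of a 1.4-fold higher number from compound 2 to compound 3 (0.14 log units; within the scatter) is therefore taken as small and uncertain, leaning towards a slightly higher number but not clearly beyond the scatter. Compound 3 is expected to give 2500 nM in this assay, with a plausible range from 700 nM to 9000 nM.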

Compound 3, half-maximal inhibitory concentration: > 10000 nM
Compound 3: a limit, no number; the forecaster's own chance of this, stated with the estimate: 10%; at least 4.0-fold (0.60 log units) between middle value and limit.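

In this assay, putting (4-(trifluoromethyl)benzyl)oxy in place of 4-bromophenyl, on an aromatic carbon para to a large group, gives an at least 5.5-fold higher number from compound 2 to compound 3 (0.74 log units; beyond the scatter). Among the compounds shown here, this is the first measured step at this position, and it shows that the read-out responds to what the position carries, so this swap is not a neutral one. Compound 3 gives > 10000 nM, which is a limit of the assay and not a number, so the step marks a minimum and the true size of the change stays unknown: the limit of > 10000 nM in this assay, at which 1 of the 3 values shown sits.

The swap alters several things at once, since the new arm brings an oxygen and a methylene link and also exchanges bromine for trifluoromethyl on the outer ring, and the compounds shown cannot say which of these parts matters. A plain benzyloxy group, a 4-(trifluoromethyl)phenyl group or a small amine at the same place would each separate these parts, and would also show whether anything here can give a lower number than compound 2 does.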